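Adding a second methoxy to the anilino ring of compound 3

This account rests on a few compounds, and the source may have more. Where it says the series, first, only, none or still open, it means among the compounds named here.

Of the compounds shown here, three sharing one core have been tested so far in a functional assay on MCF7 cells (Homo sapiens) for cytotoxicity, read by MTT assay, with a stated time of 72 h; a higher number here means a weaker inhibitor, a lower number a stronger inhibitor. Compound 1 `FC(F)(F)c1ccc(CSc2nc(Nc3ccccc3)c3ccccc3n2)cc1` gives 44000 nM. Compound 2 `FC(F)(F)c1ccc(CSc2nc(Nc3ccc(Cl)cc3)c3ccccc3n2)cc1` carries a chloro on the anilino ring and gives 21500 nM, and compound 3 `COc1ccc(Nc2nc(SCc3ccc(C(F)(F)F)cc3)nc3ccccc23)cc1` carries a methoxy there and gives 47200 nM. Among these three numbers compound 3 stands highest, but its gap to compound 1 is within the scatter; only compound 2 is clearly apart, as a 2.2-fold higher number from compound 2 to compound 3 (0.34 log units; beyond the scatter) shows.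

The next compound, compound 4 `COc1ccc(Nc2nc(SCc3ccc(C(F)(F)F)cc3)nc3ccccc23)cc1OC`, differs from compound 3 by methoxy in place of hydrogen on an aromatic carbon. Within the data shown here, the one measured step of the same kind is a 1.1-fold higher number from compound 1 to compound 3 (0.03 log units; within the scatter), which stayed within the scatter. The other steps, a 2.0-fold lower number from compound 1 to compound 2 (0.31 log units; beyond the scatter) and a 2.2-fold higher number from compound 2 to compound 3 (0.34 log units; beyond the scatter), are modest and concern a chloro rather than a methoxy, so they say less about this change. On that basis no step beyond the scatter is expected from compound 3 to compound 4 in this assay, that is a 1.0-fold lower number from compound 3 to compound 4 (0.02 log units; within the scatter). Compound 4 is therefore estimated at 45000 nM, with a plausible range from 20000 nM to 100000 nM.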

Compound 4, half-maximal inhibitory concentration: > 50000 nM
Compound 4: no number, only a limit (the forecaster's own chance of this, stated with the estimate: 10%); middle value at least 1.1-fold (0.04 log units) away from the limit.
By their numbers in this assay, from the lowest: compound 2; then compounds 1 and 3 (each within the scatter of the next). At a limit, above all of these: compound 4.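

Compound 4 has no number in this assay, only a limit of the assay: the limit of > 50000 nM in this assay, at which 1 of the 4 values shown sits. What can be read is a floor, an at least 1.0-fold higher number from compound 3 to compound 4 (0.02 log units; that floor lies within the scatter), so going from 4-methoxyphenyl to 3,4-dimethoxyphenyl, with the new methoxy ortho to a methoxy group, brought no lower number, and the data do not show how much higher the true value lies. Against the unsubstituted phenyl the floor is likewise small, an at least 1.1-fold higher number from compound 1 to compound 4 (0.05 log units; that floor lies within the scatter), and only the comparison with the chloro compound clears the scatter, an at least 2.3-fold higher number from compound 2 to compound 4 (0.36 log units; beyond the scatter), which adds the first sign that a methoxy at this place gives no gain, though it does not prove a loss.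

On these data alone, it remains open whether a different group at this same place, such as a hydroxyl, an amine or a carboxylic acid, would give a measurable number lower than those of the methoxy compounds. Among these compounds, also open is whether a second chloro here would give a lower number than the single chloro of compound 2, which stands at 21500 nM, since every change so far sits on the anilino ring alone.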